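The compounds below may be only part of what the source reports. "The series", "measured", "known", "first", "only" and "open" are said of these compounds alone.

Working notes on the series. In an assay on isolated protein for inhibition of protoporphyrinogen oxidase (Homo sapiens), read by capillary electrophoresis (a higher number here means a weaker inhibitor, a lower number a stronger inhibitor), compound 1 `CCOC(=O)CSc1nc2cc(-n3nc(C(C)(C)C)sc3=O)c(F)cc2s1` gives 340 nM, the lowest of the two numbers in hand. Among the compounds with values here, its one neighbour, compound 2 `CCOC(=O)CCCSc1nc2cc(-n3nc(C(C)(C)C)sc3=O)c(F)cc2s1`, gives 8670 nM in this assay; the single measured step, a 26-fold higher number from compound 1 to compound 2 (1.41 log units; beyond the scatter), concerns the chain on the sulfur and is large.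

Compound 3 `CCOC(=O)CSc1nc2cc(-n3nc(C(C)(C)C)sc3=O)c(Cl)cc2s1` is the next case: chloro in place of fluoro on an aromatic carbon. Within the data shown here, this change sits on the ring and leaves the sulfur-bound chain untouched, so the step from compound 1 to compound 2 does not bear on it, and no measured step covers an exchange of this halogen. With nothing to point either way, the expectation for compound 3 is no step beyond the scatter, that is no change at the digits printed from compound 1 to compound 3 (within the scatter) in this assay. The estimate for compound 3 is 340 nM, expected to fall between 110 nM and 1050 nM.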

Compound 3, inhibition constant: 5820 nM
Compound 3: the middle estimate sits 17-fold (1.23 log units) below what was measured, outside the stated range (above it).
By their numbers in this assay, from the lowest: compound 1; then compounds 3 and 2 (each within the scatter of the next).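

In this assay the aromatic carbon carrying the halogen is also sensitive: chloro in place of fluoro gives a 17-fold higher number from compound 1 to compound 3 (1.23 log units; beyond the scatter) and thus a large step, although one heavy atom replaces one heavy atom and the counted donors, acceptors and net charge stay the same. Compound 1 therefore has two separate places where a single change gives a large step, the ring halogen and the chain on the sulfur, where the other step is a 26-fold higher number from compound 1 to compound 2 (1.41 log units; beyond the scatter) in the same direction. Nothing in hand gives a measured basis for the halogen step.

Going by these compounds, whether hydrogen, bromo, methyl or methoxy at this aromatic carbon would stay close to compound 1 remains open. Also open, on these data alone, is how a carboxylic acid in place of the ethyl ester would fare with fluoro or chloro on the ring.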